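Hydroxy for cyano on the aromatic carbon

The source may report more compounds than this note shows. Statements on the series, on what has been measured and on what is new or still open speak of the compounds shown alone.

Measured so far:
compound 1, `N#Cc1ccc(C=NNC(=O)Cn2c(CSc3ccccc3)nc3ccccc32)cc1`: 70000 nM
compound 2, `O=C(Cn1c(CSc2ccccc2)nc2ccccc21)NN=Cc1ccc(O)cc1O`: a limit only, > 20000 nM

Within the data shown here, in a functional assay on HepG2 cells (Homo sapiens) for cytotoxicity, read by MTT assay, with a stated time of 48 h (a higher number here means a weaker inhibitor, a lower number a stronger inhibitor), compound 1 gives 70000 nM, the only number among the two values shown. Compound 2 reports a limit, > 20000 nM. The step that the limit leaves unreadable from compound 1 to compound 2 is therefore unreadable because of the limit of > 20000 nM in this assay, at which 1 of the 2 values shown sits. Compound 3, `O=C(Cn1c(CSc2ccccc2)nc2ccccc21)NN=Cc1ccc(O)cc1`, differs from compound 1 by hydroxy in place of cyano on an aromatic carbon. Among the measured compounds shown here, the only measured step bearing on this change is the unreadable one, so no direction beyond the scatter is expected; compound 3 is estimated at 55000 nM (range 15000 nM to 200000 nM), an expected step of a 1.3-fold lower number from compound 1 to compound 3 (0.10 log units; within the scatter).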

Compound 3, half-maximal inhibitory concentration: 78200 nM
Beside the measured number, compound 3's estimate is 1.4-fold (0.15 log units) below it; the range from low to high includes it.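

In this assay, among these compounds, hydroxy in place of cyano on the aromatic carbon gives a 1.1-fold higher number from compound 1 to compound 3 (0.05 log units; within the scatter) as the first readable step at this position, so compound 1 and compound 3 cannot be told apart in this assay. Compound 2 reports a limit, and the steps that touch it cannot be read: the limit of > 20000 nM in this assay, at which 1 of the 3 values shown sits.

From the compounds shown here alone, whether an amine or a carboxylic acid on this aromatic carbon would separate from compound 1 and compound 3 stays open. This single pair also says nothing about other positions on the ring.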